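A few compounds are considered here, and "the series" means these few. Any claim that something is new, unique, unknown or untested is made for them only; others in the source may bear on it.

Working notes on the series. The shared core of compound 1 `CONc1nc(C#Cc2ccccn2)nc2c1ncn2[C@@H]1O[C@H](CO)[C@@H](O)[C@H]1O` and compound 2 `CNC(=O)[C@H]1O[C@@H](n2cnc3c(NOC)nc(I)nc32)[C@H](O)[C@@H]1O` carries a methoxyamino group and a sugar; the two compounds differ in two places, at the sugar and at the group on the ring carbon between two ring nitrogen atoms. In an assay on CHO cells for displacement of a labelled ligand from adenosine receptor A1 (Homo sapiens) (a higher number here means a weaker inhibitor, a lower number a stronger inhibitor), compound 1 gives 437 nM, and compound 2 gives 153 nM. Compound 2 thus holds the lower of the two numbers, the gap to compound 1 lying beyond the scatter; as the two differ in two places, the numbers alone do not tell which change accounts for it.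

Compound 3 `CNC(=O)[C@H]1O[C@@H](n2cnc3c(NOC)nc(C#Cc4ccccn4)nc32)[C@H](O)[C@@H]1O` keeps the sugar of compound 2 and changes only one place: 2-(pyridin-2-yl)ethynyl in place of iodo on an aromatic carbon. No pair of measured compounds differing in this one place is on hand, so the size of the step can only be guessed from the two numbers shown. Compound 1, carrying the same 2-(pyridin-2-yl)ethynyl group, shows the higher number; the expected step from compound 2 to compound 3 is therefore a 2.0-fold higher number from compound 2 to compound 3 (0.29 log units; within the scatter), a modest rise that may still fall within the scatter. For compound 3 in this assay the estimate is 300 nM, within 100 nM to 1000 nM.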

Compound 3, inhibition constant: 3990 nM
For compound 3 the middle estimate is 13-fold (1.12 log units) below the measured one, outside the stated range (above it).
By their numbers in this assay, from the lowest: compound 2; then compound 1; then compound 3.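

In this assay, with the methylcarbamoyl sugar held fixed, 2-(pyridin-2-yl)ethynyl in place of iodo on the ring carbon between two ring nitrogen atoms gives a 26-fold higher number from compound 2 to compound 3 (1.42 log units; beyond the scatter), so this position responds strongly to this change. With 2-(pyridin-2-yl)ethynyl held fixed, methylcarbamoyl in place of hydroxymethyl on a saturated ring carbon gives a 9.1-fold higher number from compound 1 to compound 3 (0.96 log units; beyond the scatter), so the sugar change also moves the number beyond the scatter, and in the same direction. No measured data bear on the reason for either step.

The compounds shown leave open whether the rise at the aromatic carbon follows the triple bond, the pyridine ring or the replacement of iodo as such; a plain ethynyl group or a phenylethynyl group at this carbon would help separate these. As far as these compounds go, it also remains open whether the sugar step has the same size and direction when iodo occupies this carbon, since the step is read here only with 2-(pyridin-2-yl)ethynyl in place.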